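A few compounds are considered here, and "the series" means these few. Any claim that something is new, unique, unknown or untested is made for them only; others in the source may bear on it.

Compound 1 `CCCOCCn1c(N2CCN(C)CC2)nc2ccccc21` gives 20 nM in a functional assay on ileum for inhibition of histamine H1 receptor (Cavia porcellus); on this read-out higher numbers stand for weaker inhibition and lower numbers for stronger inhibition.
Compound 2 `CCCCCCn1c(N2CCN(C)CC2)nc2ccccc21` gives 26 nM in this assay.
Compound 3 `COCCn1c(N2CCN(C)CC2)nc2ccccc21` gives 13 nM in this assay.

The three measured compounds share one core and differ only in the chain on the aromatic nitrogen. Compound 3 shows the lowest of the three numbers, but its gaps to the others stay within the scatter: a 1.5-fold lower number from compound 1 to compound 3 (0.19 log units; within the scatter) and a 2.0-fold lower number from compound 2 to compound 3 (0.30 log units; within the scatter). The step of a 1.3-fold higher number from compound 1 to compound 2 (0.11 log units; within the scatter) is likewise within the scatter, so across these three compounds no change beyond the scatter is seen.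

Compound 4 `CCCCCCCCCCn1c(N2CCN(C)CC2)nc2ccccc21` differs from compound 3 in this way: octyl in place of methoxy on a saturated chain carbon, two bonds along the chain from an aromatic nitrogen. Among the compounds with values here, the step that bears most directly on it is the one from compound 2 to compound 3, where a methoxy took the place of a butyl at the same carbon; that step was small. Within the data shown here, compound 4 carries a longer chain than any measured compound, so the data give no step of this size. Compound 4 is therefore expected to lie close to the measured range, with a 2.3-fold higher number from compound 3 to compound 4 (0.36 log units; beyond the scatter) anticipated as a modest rise, and its estimated value is 30 nM, within 10 nM to 100 nM.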

Compound 4, half-maximal inhibitory concentration: 4200 nM
The estimate for compound 4 lay 140-fold (2.15 log units) below the measured number; the whole stated range lies below it.
By their numbers in this assay, from the lowest: compounds 3, 1 and 2 (each within the scatter of the next); then compound 4.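

In this assay, methoxy, propoxy and butyl on the saturated chain carbon, two bonds along the chain from an aromatic nitrogen, had stayed within the scatter of one another, whereas octyl there brings far weaker inhibition (a 320-fold higher number from compound 3 to compound 4 (2.51 log units; beyond the scatter)) and (a 210-fold higher number from compound 1 to compound 4 (2.32 log units; beyond the scatter)). The all-carbon chain also shows that length alone can matter here, since butyl in place of hydrogen on a saturated chain carbon, six bonds along the chain from an aromatic nitrogen, gives (a 160-fold higher number from compound 2 to compound 4 (2.21 log units; beyond the scatter)). No measurement shown accounts for this loss of inhibition.

The compounds shown leave open whether the rise builds gradually or sets in abruptly, which pentyl or hexyl in the same place could test. They also leave open whether an amine or a hydroxyl at the end of the octyl chain would bring the number back down.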